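The source may hold more compounds than are shown below. What is called first, only, known or untested is meant among the compounds shown, and "the series" means these compounds.

Measured so far, in an in vitro functional assay on cells for agonist activity at Bombesin receptor subtype-3 (Mus musculus), read by luminescence and calcium flux; a lower number here means that less compound is needed, a higher number that more compound is needed for the effect:

- compound 1 `Cc1ccccc1Cc1cnc(CCc2ccc(-c3ccccc3C(=O)O)cc2)[nH]1` gives 9.3 nM
- compound 2 `Cc1cccc(Cc2cnc(CCc3ccc(-c4ccccc4C(=O)O)cc3)[nH]2)c1` gives 75 nM
- compound 3 `N#Cc1cccc(Cc2cnc(CCc3ccc(-c4ccccc4C(=O)O)cc3)[nH]2)c1` gives 20 nM

Compound 1 stands lowest of the three numbers in this assay, that is, it needs the least compound. Its nearest neighbour is compound 3, with a 2.2-fold higher number from compound 1 to compound 3 (0.33 log units; beyond the scatter), and its furthest is compound 2, with an 8.1-fold higher number from compound 1 to compound 2 (0.91 log units; beyond the scatter).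

Compound 4 `N#Cc1ccccc1Cc1cnc(CCc2ccc(-c3ccccc3C(=O)O)cc2)[nH]1` has not yet been measured. It differs from compound 1 in one place: cyano in place of methyl on an aromatic carbon.

Going by the values given here, one measured step bears directly on this change: cyano in place of methyl on an aromatic carbon, seen as a 3.8-fold lower number from compound 2 to compound 3 (0.57 log units; beyond the scatter), where the group sits in the 3-position of the phenyl rather than ortho to the large group. Whether the same gain carries over to the 2-position is not known from these three compounds; the two methyl compounds, compound 1 and compound 2, already show that the position of the group matters a good deal. With wide uncertainty, the step expected for compound 4 in this assay is therefore a 1.9-fold lower number from compound 1 to compound 4 (0.27 log units; within the scatter).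

Compound 4 is thus estimated at 5 nM in this assay, with a range from 1.5 nM to 18 nM.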

Compound 4, half-maximal effective concentration: 642 nM
Compound 4: the middle estimate sits 130-fold (2.11 log units) below what was measured; measured number above the stated range.
By their numbers in this assay, from the lowest: compound 1; then compound 3; then compound 2; then compound 4.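

In this assay, the swap of methyl for cyano does not carry one effect from one place on the phenyl to another, and the two placements go in opposite directions: the same change on two cores in this assay, a 3.8-fold lower number (0.57 log units; beyond the scatter) from compound 2 to compound 3 and a 69-fold higher number (1.84 log units; beyond the scatter) from compound 1 to compound 4, 260-fold (2.41 log units) apart, beyond the scatter of two such steps.

On the carbon ortho to a large group, the same swap gives a 69-fold higher number from compound 1 to compound 4 (1.84 log units; beyond the scatter) and turns the best of the methyl placements into the worst of the cyano ones, and changing 3-cyanophenyl to 2-cyanophenyl gives a 32-fold higher number from compound 3 to compound 4 (1.51 log units; beyond the scatter) on an otherwise unchanged structure. Compound 4 also sits past the highest of the earlier numbers, with an 8.6-fold higher number from compound 2 to compound 4 (0.93 log units; beyond the scatter) in a step that alters both the group and its place, so a good result for 2-methylphenyl says little about what else is accepted on that carbon.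

From the compounds shown here alone, only methyl and cyano appear on this carbon, so whether chloro or methoxy there would behave like the first or like the second remains open. The compounds shown also do not tell why the two placements part so sharply, or whether the same split would hold on a longer chain in place of the one linking the phenyl to the core.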